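Shifting a Cyanophenyl to a Methoxyphenyl on the Triazole

The source may hold more compounds than are shown below. What is called first, only, known or untested is meant among the compounds shown, and "the series" means these compounds.

Measured compounds:
compound 1 `CC1(C)[C@H]2CC[C@]1(C)N(Cc1cn(-c3ccccc3C#N)nn1)C(=O)C2` 180 nM
compound 2 `CC1(C)[C@H]2CC[C@]1(C)N(Cc1cn(-c3cccc(C#N)c3)nn1)C(=O)C2` 40 nM
compound 3 `CC1(C)[C@H]2CC[C@]1(C)N(Cc1cn(-c3ccccc3Cl)nn1)C(=O)C2` 60 nM

Of the compounds shown here, three sharing one core have been tested in a functional assay on HepG2 cells (Homo sapiens) for inhibition, read by MTT assay, with a stated time of 24 h; a lower number here means a stronger inhibitor, a higher number a weaker inhibitor. Compound 1 gives the highest number of the three: the step of a 3.0-fold lower number from compound 1 to compound 3 (0.48 log units; beyond the scatter) is its nearest neighbour, and the step of a 4.5-fold lower number from compound 1 to compound 2 (0.65 log units; beyond the scatter) its furthest. The two lower numbers sit close together, as the step of a 1.5-fold higher number from compound 2 to compound 3 (0.18 log units; within the scatter) shows.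

Compound 4 `COc1cccc(-n2cc(CN3C(=O)C[C@@H]4CC[C@@]3(C)C4(C)C)nn2)c1` has not yet been measured. It differs from compound 1 in one place: 3-methoxyphenyl in place of 2-cyanophenyl on an aromatic nitrogen. For the measured compounds named here, two measured steps bear on this change. Moving the cyano group from the 2-position to the 3-position lowered the number, as seen in a 4.5-fold lower number from compound 1 to compound 2 (0.65 log units; beyond the scatter), and exchanging the cyano group for another substituent also lowered it, as seen in a 3.0-fold lower number from compound 1 to compound 3 (0.48 log units; beyond the scatter). Going by the values given here, no measured compound carries a methoxy group, so the size of that exchange is unknown. A modest lowering beyond the scatter is therefore expected, of roughly a 3.3-fold lower number from compound 1 to compound 4 (0.51 log units; beyond the scatter). Compound 4 is estimated at 55 nM in this assay, between 20 nM and 160 nM.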

Compound 4, half-maximal inhibitory concentration: 70 nM
Estimate against measurement, compound 4: 1.3-fold (0.10 log units) below, within the range that was stated.
By their numbers in this assay, from the lowest: compounds 2, 3 and 4 (each within the scatter of the next); then compound 1.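

In this assay the 3-methoxyphenyl group also departs from the 2-cyanophenyl result, with a 2.6-fold lower number from compound 1 to compound 4 (0.41 log units; beyond the scatter) as the step, so a third group on the aromatic nitrogen now joins the lower numbers. Methoxy in place of cyano on the same aromatic carbon gives a 1.8-fold higher number from compound 2 to compound 4 (0.24 log units; within the scatter) and so stays within the scatter, which shows that this exchange does not separate the two groups here. The comparison with the chlorinated compound gives a 1.2-fold higher number from compound 3 to compound 4 (0.07 log units; within the scatter) and is also within the scatter, leaving compound 1 as the weakest of the four and the only one set apart.

Nothing measured alongside these numbers accounts for the result. As far as these compounds go, whether methoxy placed where compound 1 carries its nitrile would give a higher number, and whether an amine or a carboxylic acid on the phenyl ring would stay level with compound 4, remains open.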